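The compounds below may be only part of what the source reports. "The series", "measured", "known", "first", "only" and "open" are said of these compounds alone.

Measured compounds:
compound 1 `O=c1cc(/C=C/C=C/c2ccc(O)c(O)c2)oc2ccccc12` — 32000 nM
compound 2 `O=c1cc(/C=C/C=C/c2ccc(O)c(O)c2)oc2cccc(O)c12` — 94000 nM

In a physicochemical assay for inhibition, read by fluorescence, at 37 degrees C (a lower number here means a stronger inhibitor, a higher number a weaker inhibitor), compound 1 gives the lowest of the two numbers; its nearest neighbour is compound 2, a step of a 2.9-fold higher number from compound 1 to compound 2 (0.47 log units; beyond the scatter). Compound 3 `O=c1cc(/C=C/C=C/c2ccc(O)c(O)c2)oc2cc(O)ccc12` differs from compound 1 by hydroxy in place of hydrogen on an aromatic carbon. Within the data shown here, the only step that bears on this change is the one from compound 1 to compound 2, where a hydroxy also entered the same ring, with a modest weakening. Compound 3 is therefore expected to show a step of similar or smaller size in the same direction, a 1.6-fold higher number from compound 1 to compound 3 (0.19 log units; within the scatter). The estimate for compound 3 in this assay is 50000 nM, with a range from 20000 nM to 120000 nM.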

Compound 3, half-maximal inhibitory concentration: 17000 nM
Compound 3: the middle estimate sits 2.9-fold (0.47 log units) above what was measured; the whole stated range lies above it.
By their numbers in this assay, from the lowest: compounds 3 and 1 (each within the scatter of the next); then compound 2.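

In this assay hydroxy in place of hydrogen, on the aromatic carbon meta to a fused ring and para to a fused ring, gives a 1.9-fold lower number from compound 1 to compound 3 (0.27 log units; within the scatter) and so leaves compound 3 indistinguishable from compound 1. The hydroxy of compound 2 gave a 2.9-fold higher number from compound 1 to compound 2 (0.47 log units; beyond the scatter) and so, across these three compounds, the outcome of this change depends on where the hydroxy sits. No measured evidence accounts for this difference. The compounds shown leave open whether a methoxy group or an amine on this carbon would give a number apart from that of compound 1.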